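The source may report more compounds than this note shows. Statements on the series, on what has been measured and on what is new or still open speak of the compounds shown alone.

Three compounds have been measured in an assay on cell membranes for binding affinity to Equilibrative nucleoside transporter 1 (Homo sapiens); a lower number here means a stronger inhibitor, a higher number a weaker inhibitor:
compound 1 `CNc1nc2c(SCc3ccccc3)ncnc2n1C1O[C@H](CO)[C@@H](O)[C@H]1O` with 28 nM;
compound 2 `CCCCNc1nc2c(SCc3ccccc3)ncnc2n1C1O[C@H](CO)[C@@H](O)[C@H]1O` with 5.4 nM;
compound 3 `CCC(C)CNc1nc2c(SCc3ccccc3)ncnc2n1C1O[C@H](CO)[C@@H](O)[C@H]1O` with 3.6 nM.

Among the compounds with values here, compound 3 gives the lowest of the three numbers, yet the step of a 1.5-fold lower number from compound 2 to compound 3 (0.18 log units; within the scatter) lies within the scatter and only the step of a 7.8-fold lower number from compound 1 to compound 3 (0.89 log units; beyond the scatter) lies beyond it. Compound 4 `OC[C@H]1OC(n2c(N3CCCC3)nc3c(SCc4ccccc4)ncnc32)[C@H](O)[C@@H]1O` differs from compound 3 by pyrrolidin-1-yl in place of (2-methylbutyl)amino on an aromatic carbon. The measured steps all concern the chain on that amine: a 5.2-fold lower number from compound 1 to compound 2 (0.71 log units; beyond the scatter) and a 7.8-fold lower number from compound 1 to compound 3 (0.89 log units; beyond the scatter) lower the number well beyond the scatter, while a 1.5-fold lower number from compound 2 to compound 3 (0.18 log units; within the scatter) stays within it. Within the data shown here, no measured step removes the amine hydrogen or closes a ring, so that part of the change is untested. For compound 4 a step of a 1.9-fold higher number from compound 3 to compound 4 (0.29 log units; within the scatter) is expected, with the estimate 7 nM in the range 2.5 nM to 20 nM.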

Compound 4, inhibition constant: 410 nM
Compound 4: middle estimate off by 59-fold (1.77 log units), on the low side; measured number above the stated range.
By their numbers in this assay, from the lowest: compounds 3 and 2 (each within the scatter of the next); then compound 1; then compound 4.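

Putting pyrrolidin-1-yl on this aromatic carbon costs far more than any change of chain on the amine did, with a 110-fold higher number from compound 3 to compound 4 (2.06 log units; beyond the scatter) and a 76-fold higher number from compound 2 to compound 4 (1.88 log units; beyond the scatter). Even against methylamino the step is a 15-fold higher number from compound 1 to compound 4 (1.17 log units; beyond the scatter), so all three open-chain amines that keep the amine hydrogen give lower numbers than the ring does. Nothing available explains this loss.

On these data alone, whether it follows from losing the amine hydrogen or from closing the ring remains open. A dimethylamino group, which has no amine hydrogen and no ring, would separate the two.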